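The source may hold more compounds than are shown below. What is called first, only, known or untested is meant among the compounds shown, and "the series" means these compounds.

Of the compounds shown here, three sharing one core have been measured in an assay on isolated protein for inhibition of G protein-coupled receptor kinase 6 (Homo sapiens), read by scintillation counting, radiometric assay and 33P incorporation, with a stated time of 80 min, in the presence of a further agent that is not named here; on this read-out higher numbers stand for weaker inhibition and lower numbers for stronger inhibition. Compound 1 `CCc1cc(Nc2nc(N[C@@H](C)c3ccc(F)cc3)nc3ccc(F)cc23)n[nH]1` gives 160 nM, the highest of the three numbers. Compound 2 `CCc1cc(Nc2nc(N[C@@H](C)c3ccc(Cl)cn3)nc3cccc(OC)c23)n[nH]1` gives 3.5 nM, and compound 3 `CCc1cc(Nc2nc(N[C@@H](C)c3ccc(F)cn3)nc3cccc(C)c23)n[nH]1` gives 11 nM. Both of those numbers lie well beyond the scatter from compound 1, so compound 1 is the weakest inhibitor among the three. No two of these compounds differ in only a single place, so no isolated structural change can yet be read off from the measured set.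

Compound 4 `CCc1cc(Nc2nc(N[C@@H](C)c3ccc(F)cc3)nc3ccc(OC)cc23)n[nH]1` has not yet been measured. It differs from compound 1 by one change: methoxy in place of fluoro on an aromatic carbon. Compound 2, which also carries a methoxy on its core, gives 3.5 nM, but it differs from compound 1 in more than one place, so that number is only a loose guide. A moderate step toward stronger inhibition is expected, a 2.3-fold lower number from compound 1 to compound 4 (0.36 log units; beyond the scatter). Compound 4 is therefore estimated at 70 nM, with a likely range from 20 nM to 250 nM.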

Compound 4, half-maximal inhibitory concentration: 140 nM
Compound 4: middle estimate off by 2.0-fold (0.30 log units), on the low side; measured number inside the range.
By their numbers in this assay, from the lowest: compound 2; then compound 3; then compounds 4 and 1 (each within the scatter of the next).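

Methoxy in place of fluoro on this aromatic carbon of the shared core gives a 1.1-fold lower number from compound 1 to compound 4 (0.06 log units; within the scatter) in this assay. For the compounds shown here, this is the first comparison in the set that changes only one place, and at this position the two groups cannot be told apart, although methoxy, unlike fluoro, counts as a hydrogen-bond acceptor. No measurement available here bears on the reason for this result.

From the compounds shown here alone, whether an amine or a longer chain such as ethoxy on this carbon would also leave the number within the scatter remains open, as does whether methoxy would behave the same way on another carbon of the core. Compound 2 and compound 3 each differ from compound 1 in several places at once, so the part played by each of those changes cannot yet be separated.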